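The compounds below may be only part of what the source reports. "The series", "measured", "known", "first", "only" and "open" are said of these compounds alone.

Measured in a functional assay on SK-OV-3 cells (Homo sapiens) for inhibition, read by CCK-8 assay, with a stated time of 70 h; a higher number here means a weaker inhibitor, a lower number a stronger inhibitor
compound 1 `c1ccc(COc2ccc(OCCOCCNc3ccncc3)cc2)cc1` gives 20600 nM
compound 2 `c1ccc(COc2ccc(OCCOCCNC3CCCCCC3)cc2)cc1` gives 7460 nM
compound 3 `c1ccc(COc2ccc(OCCOCCNC3CC3)cc2)cc1` gives 47200 nM

Compound 3 has the highest number of the three and is the weakest inhibitor among them, with both other compounds beyond the scatter from it. The next compound, still unmeasured, is compound 4 `c1ccc(COc2ccc(OCCOCCNC3CCOC3)cc2)cc1` with oxolan-3-yl in place of cyclopropyl on an amine nitrogen. The counted difference reads oxolan-3-yl in place of cyclopropyl on an amine nitrogen and it keeps the shared core and the chain unchanged.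

The relevant evidence comes from the three measured changes on the same amine nitrogen. The largest is a 6.3-fold higher number from compound 2 to compound 3 (0.80 log units; beyond the scatter) and the smaller one involving cyclopropyl is a 2.3-fold higher number from compound 1 to compound 3 (0.36 log units; beyond the scatter) while the remaining one is a 2.8-fold lower number from compound 1 to compound 2 (0.44 log units; beyond the scatter) and all three are modest. Both other groups tested at this place thus give lower numbers than cyclopropyl. Within the data shown here, no measured compound carries oxolan-3-yl or another saturated ring with a hetero atom, so this direction is only weakly supported.

A small move toward a lower number is therefore expected in this assay and it is not expected to go clearly beyond the scatter. The expected step is a 1.7-fold lower number from compound 3 to compound 4 (0.24 log units; within the scatter) in this estimate. For compound 4 the estimated value is 27000 nM with an expected range from 12000 nM to 60000 nM as its span.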

Compound 4, half-maximal inhibitory concentration: 48000 nM
Estimate against measurement, compound 4: 1.8-fold (0.25 log units) below; the range from low to high includes it.
By their numbers in this assay, from the lowest: compound 2; then compound 1; then compounds 3 and 4 (each within the scatter of the next).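

In this assay, oxolan-3-yl and cyclopropyl on the amine nitrogen cannot be told apart (a 1.0-fold higher number from compound 3 to compound 4 (0.01 log units; within the scatter)), although the entering group brings a five-membered ring with one hetero atom and one hydrogen-bond acceptor. Compound 4 shows the same separation from the other two groups as cyclopropyl does (a 6.4-fold higher number from compound 2 to compound 4 (0.81 log units; beyond the scatter); a 2.3-fold higher number from compound 1 to compound 4 (0.37 log units; beyond the scatter)), so among the four compounds, only cycloheptyl and pyridin-4-yl give clearly lower numbers at this place. Nothing measured on these compounds bears on why oxolan-3-yl and cyclopropyl read alike.

Cyclopentyl, an all-carbon ring of the same size as oxolan-3-yl, would show whether the ring oxygen matters here. From the compounds shown here alone, how a piperidin-4-yl group, which carries a second amine in its ring, or an open hexyl chain would read on this amine nitrogen also stays open, as does whether the low number of compound 2 belongs to cycloheptyl specifically or to large carbon groups in general.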